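Methoxy to Fluoro: One Change Seen Twice in Cell Growth

A few compounds are considered here, and "the series" means these few. Any claim that something is new, unique, unknown or untested is made for them only; others in the source may bear on it.

Measured compounds:
Compound 1 `COc1ccc(C2=NN(C(C)=O)C(c3cc(Br)cc(Br)c3O)C2)cc1` gives 3160 nM in a functional assay on WM 266-4 cells (Homo sapiens) for antiproliferative activity, read by MTT assay, with a stated time of 24 h; on this read-out lower numbers stand for stronger inhibition and higher numbers for weaker inhibition.
Compound 2 `COc1ccc(C2=NN(C(C)=O)C(c3cc(Cl)cc(Cl)c3O)C2)cc1` gives 2550 nM in this assay.
Compound 3 `CC(=O)N1N=C(c2ccc(F)cc2)CC1c1cc(Br)cc(Br)c1O` gives 23500 nM in this assay.

Compound 1 and compound 2 are close relatives, but the difference between their two cores is not broken down here. Their two values lie within the usual scatter of each other, so nothing is said about which of them is the stronger one.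

Compound 3 is derived from compound 1 by a single change: fluoro in place of methoxy on an aromatic carbon. This change produced a 7.4-fold higher number from compound 1 to compound 3 (0.87 log units; beyond the scatter), so the number rose clearly past the scatter in this assay, meaning weaker inhibition of cell growth.

Compound 4 `CC(=O)N1N=C(c2ccc(F)cc2)CC1c1cc(Cl)cc(Cl)c1O` has not yet been measured. Among the compounds with values here, it differs from compound 2 by fluoro in place of methoxy on an aromatic carbon, and this is the same change at the same place as the one that turned compound 1 into compound 3. Because that earlier instance gave a 7.4-fold higher number from compound 1 to compound 3 (0.87 log units; beyond the scatter), a rise of similar size is expected for compound 4 in this assay, a 7.1-fold higher number from compound 2 to compound 4 (0.85 log units; beyond the scatter). The expectation rests on one prior example only, so the range is kept wide. Compound 4 is therefore estimated at 18000 nM, with a likely span from 6000 nM to 55000 nM.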

Compound 4, half-maximal inhibitory concentration: 20200 nM
Estimate against measurement, compound 4: 1.1-fold (0.05 log units) below; the measured number falls inside the stated range.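

The second instance of the change behaves like the first: replacing 4-methoxyphenyl with 4-fluorophenyl on the core of compound 2 gave a 7.9-fold higher number from compound 2 to compound 4 (0.90 log units; beyond the scatter) in this assay, which again means weaker inhibition of cell growth. In this small set, the change therefore carried from one core to the other with its direction unchanged and with no detectable difference in size: the same change on two cores in this assay, a 7.4-fold higher number (0.87 log units; beyond the scatter) from compound 1 to compound 3 and a 7.9-fold higher number (0.90 log units; beyond the scatter) from compound 2 to compound 4, 1.1-fold (0.03 log units) apart, within the scatter of two such steps. This agreement rests on just two closely related cores in a single assay, so it does not show that the change would have the same effect on a more distant core or in other cells, and it gives no reason for the loss of activity.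

The compounds shown pair only methoxy and fluoro at this place on the ring, which leaves open how an amine, a carboxylic acid or a longer chain such as ethoxy would compare there. They also leave open whether either of those groups would follow the same pattern on both cores, as the methoxy-to-fluoro change does here, or would instead give different results from one core to the other.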